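The source may report more compounds than this note shows. Statements on the series, on what has been measured and on what is new or still open speak of the compounds shown alone.

Four compounds share one core. Within the data shown here, compound 1 `CC1(C)OC[C@@H]2O[C@H](COCc3ccccc3)[C@@H](OCc3ccccc3)[C@H](OCc3ccccc3)[C@H]2O1` is the only member with a number in a functional assay on HL-60 cells (Homo sapiens) for antiproliferative activity, read by MTT assay; a higher number here means a weaker inhibitor, a lower number a stronger inhibitor: compound 1 gives 12500 nM. Compound 2 `C#CC[C@@H]1O[C@H](COCc2ccccc2)[C@@H](OCc2ccccc2)[C@H](OCc2ccccc2)[C@H]1O` is reported in this assay as "not active" (no number reported), and compound 3 `CC(=O)OC[C@@H]1O[C@H](COCc2ccccc2)[C@@H](OCc2ccccc2)[C@H](OCc2ccccc2)[C@H]1OCc1ccccc1` likewise gives "not active" (no number reported). Compound 2 thus stands without a single number, alongside one further entry that also has none, and only compound 1 anchors the scale. The step to compound 4 `CCC[C@@H]1O[C@H](COCc2ccccc2)[C@@H](OCc2ccccc2)[C@H](OCc2ccccc2)[C@H]1O` changes (ethyl in place of ethynyl on a saturated chain carbon bound to a saturated ring carbon). With compound 2 showing "not active" (no number reported), a step in this assay of any size, in either direction, cannot be read from the record, and nothing in it points to a gain. Compound 4 is therefore expected to remain weak, with an estimated value of 30000 nM, in the range 8000 nM to 120000 nM.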

Compound 4, half-maximal inhibitory concentration: 11700 nM
For compound 4 the middle estimate is 2.6-fold (0.41 log units) above the measured one; low and high end bracket the measured number.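

Among these compounds, compound 2 has no number in this assay, so no step to compound 4 at 11700 nM can be read. The compounds shown leave open what the change from propargyl to propyl does in this assay. No data at hand offer an explanation for the result of compound 4.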